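Cytotoxicity notes on three measured analogues and one pending

A few compounds are considered here, and "the series" means these few. Any claim that something is new, unique, unknown or untested is made for them only; others in the source may bear on it.

Measured so far, in an ADME assay on MT4 cells (Homo sapiens) for cytotoxicity, read by MTT assay, with a stated time of 96 h; on this read-out higher numbers stand for lower toxicity in this test and lower numbers for higher toxicity in this test:
compound 1 `Cc1cccc(C2CC(c3ccc(Oc4ccccc4)cc3)=NN2c2ccc(S(N)(=O)=O)cc2)c1`: 35000 nM
compound 2 `Cc1cccc(C2CC(c3ccccc3)=NN2c2ccc(S(N)(=O)=O)cc2)c1`: 37000 nM
compound 3 `Cc1ccccc1C1CC(c2ccc(Oc3ccccc3)cc2)=NN1c1ccc(S(N)(=O)=O)cc1`: 36000 nM

The three measured numbers sit together, and the two single-point steps fall inside the usual scatter: a 1.1-fold higher number from compound 1 to compound 2 (0.02 log units; within the scatter) for the change (hydrogen in place of phenoxy on an aromatic carbon), and a 1.0-fold higher number from compound 1 to compound 3 (0.01 log units; within the scatter) for the change (2-methylphenyl in place of 3-methylphenyl on a saturated ring carbon), which is also how the core of compound 3 differs from that of compound 1.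

Compound 4 `Cc1ccccc1C1CC(c2ccccc2)=NN1c1ccc(S(N)(=O)=O)cc1` is not yet measured. It differs from compound 3 by hydrogen in place of phenoxy on an aromatic carbon, the same change as from compound 1 to compound 2 at the same place. Going by the values given here, with only that one prior step, and it within scatter, the expectation is a flat result. For compound 4 the expected step is a 1.0-fold higher number from compound 3 to compound 4 (0.01 log units; within the scatter), resting on a 1.1-fold higher number from compound 1 to compound 2 (0.02 log units; within the scatter). Compound 4 is estimated at 37000 nM in this assay, with a range from 20000 nM to 70000 nM.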

Compound 4, half-maximal cytotoxic concentration: 43000 nM
Beside the measured number, compound 4's estimate is 1.2-fold (0.07 log units) below it; the measured number falls inside the stated range.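

In this assay, hydrogen in place of phenoxy gives a 1.2-fold higher number from compound 3 to compound 4 (0.08 log units; within the scatter), in line with the earlier step for the same change: the same change on two cores in this assay, a 1.1-fold higher number (0.02 log units; within the scatter) from compound 1 to compound 2 and a 1.2-fold higher number (0.08 log units; within the scatter) from compound 3 to compound 4, 1.1-fold (0.05 log units) apart, within the scatter of two such steps. Likewise, 2-methylphenyl in place of 3-methylphenyl gives a 1.2-fold higher number from compound 2 to compound 4 (0.07 log units; within the scatter), again in line with the earlier step: the same change on two cores in this assay, a 1.0-fold higher number (0.01 log units; within the scatter) from compound 1 to compound 3 and a 1.2-fold higher number (0.07 log units; within the scatter) from compound 2 to compound 4, 1.1-fold (0.05 log units) apart, within the scatter of two such steps. On these two cores, neither change gives a step beyond the scatter, but this does not show that either change would stay flat on another core or in another test.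

Still open, going by these compounds, is whether a different group on the same aromatic carbon, such as an amine or a carboxylic acid, would give a step beyond the scatter.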